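The source may report more compounds than this note shows. Statements on the series, on what has been measured and on what is new or still open speak of the compounds shown alone.

Compound 1 `CC(=O)SCC(=O)c1ccc(NS(=O)(=O)c2ccc(OC3CCCN(C)C3)cc2)nc1` gives 1200 nM in a functional assay on U226 cells (Homo sapiens) for cytotoxicity; a higher number here means that more compound is needed for the effect, a lower number that less compound is needed. Compound 2 `COCCCOc1ccc(S(=O)(=O)Nc2ccc(C(=O)CSC(C)=O)cn2)cc1` gives 29000 nM in this assay. In this assay compound 3 `CC(=O)SCC(=O)c1ccc(NS(=O)(=O)c2ccc(OCCCc3ccccn3)cc2)nc1` gives "not determined" (no result reported), so no number was reported for it. Compound 4 `CC(=O)SCC(=O)c1ccc(NS(=O)(=O)c2ccc(OC3CCN(C)CC3)cc2)nc1` is not yet measured.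

Compound 3 therefore stands nowhere on the numbers: no value was reported for it, and the step to compound 4 has no measured starting point. The change is 1-methylpiperidin-4-yl in place of 3-(pyridin-2-yl)propyl on an oxygen on an aromatic ring. Within the data shown here, no measured step covers this exchange. Among the measured compounds shown here, the only step available, a 24-fold higher number from compound 1 to compound 2 (1.38 log units; beyond the scatter), concerns a different exchange at the same oxygen and was large. Compound 4 resembles compound 1, which gives 1200 nM, more closely than any other compound shown. On that ground compound 4 is expected to land near 1500 nM, in an estimated range from 400 nM to 6000 nM.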

Compound 4, half-maximal effective concentration: 300 nM
Compound 4: middle estimate off by 5.0-fold (0.70 log units), on the high side, and the stated range ends above it.
By their numbers in this assay, from the lowest: compound 4; then compound 1; then compound 2.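

Among these compounds, at the oxygen on the aromatic ring, the attachment point of the methylpiperidine matters in this assay: 1-methylpiperidin-4-yl in place of 1-methylpiperidin-3-yl gives a 4.0-fold lower number from compound 1 to compound 4 (0.60 log units; beyond the scatter), a difference the earlier compounds could not show. Against the open chain 3-methoxypropyl, the same group gives a 97-fold lower number from compound 2 to compound 4 (1.99 log units; beyond the scatter), so both ring isomers now sit well below that chain on the printed numbers. Nothing given here accounts for either step. Steps from compound 3 cannot be read, since it has no number. Still open, going by these compounds, is how a piperidin-4-yl group without the methyl, or a 1-methylpyrrolidin-3-yl group, would behave on this oxygen.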